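The compounds below may be only part of what the source reports. "The series", "measured", "known", "first", "only" and "open" are said of these compounds alone.

Working notes on the amide series built on the shared core of compound 1 `COc1ccc(C(=O)Nc2c(F)cccc2F)cc1OC1CCCC1`. In an assay on isolated protein for inhibition of phosphodiesterase 4A (Sus scrofa) (a higher number here means a weaker inhibitor, a lower number a stronger inhibitor), compound 1 gives 70 nM; compound 2 `COc1ccc(C(=O)Nc2c(F)cccc2F)cc1` gives 37000 nM; compound 3 `CCCCOc1cc(C(=O)Nc2c(F)cccc2F)ccc1OC` gives 300 nM. Compound 3 therefore stands second highest of the three numbers, set apart by a 4.3-fold higher number from compound 1 to compound 3 (0.63 log units; beyond the scatter) and by a 120-fold lower number from compound 2 to compound 3 (2.09 log units; beyond the scatter). Every measured step, including a 530-fold higher number from compound 1 to compound 2 (2.72 log units; beyond the scatter), concerns the cyclopentyloxy or butoxy side of the core, and none concerns the group on the amide-type nitrogen. Compound 4 `CCCCOc1cc(C(=O)Nc2c(Cl)cncc2Cl)ccc1OC` differs from compound 3 by 3,5-dichloropyridin-4-yl in place of 2,6-difluorophenyl on an amide-type nitrogen. Among the measured compounds shown here, no measured step bears on this change, so the expectation rests on the structural change alone and carries a wide range. For compound 4 in this assay the estimated value is 100 nM (range 15 nM to 700 nM), meaning an expected step of a 3.0-fold lower number from compound 3 to compound 4 (0.48 log units; beyond the scatter).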

Compound 4, half-maximal inhibitory concentration: 8 nM
The estimate for compound 4 lay 13-fold (1.10 log units) above the measured number; the measured number lies below the stated range.
By their numbers in this assay, from the lowest: compound 4; then compound 1; then compound 3; then compound 2.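

Among the compounds shown here, with the group on the amide-type nitrogen changed, this assay gives a 38-fold lower number from compound 3 to compound 4 (1.57 log units; beyond the scatter), so this position, untouched by the earlier steps, strongly affects the number. The change replaces carbon with a ring nitrogen, adds a hydrogen-bond acceptor and swaps fluorine for chlorine all at once, and the single step cannot apportion its size among these. No measurement available here accounts for the step. Open, from the compounds shown here alone, is whether 2,6-dichlorophenyl or plain pyridin-4-yl would separate the chlorine from the ring nitrogen. Also open, going by these compounds, is whether 3,5-dichloropyridin-4-yl gives a similar step with cyclopentyloxy in place of butoxy.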